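Methyl on sulfur: expected cytotoxicity of compound 3

The compounds below may be only part of what the source reports. "The series", "measured", "known", "first", "only" and "open" are said of these compounds alone.

Going by the values given here, compound 1, `C[Se]c1nc(N)c2ccccc2n1`, and compound 2, `Sc1nc(NCc2ccccc2)c2ccccc2n1`, are the two measured members. In a functional assay on HT-29 cells (Homo sapiens) for cytotoxicity, read by MTT assay, with a stated time of 72 h (on this read-out lower numbers stand for higher toxicity in this test and higher numbers for lower toxicity in this test), compound 1 gives > 100000 nM, a limit of the assay rather than a number. In this assay compound 2 likewise gives > 100000 nM, again a limit. Compound 2 thus stands at the limit of > 100000 nM in this assay, at which 2 of the 2 values shown sit; nothing separates it from compound 1 or places it within the measured range.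

Compound 3, `CSc1nc(NCc2ccccc2)c2ccccc2n1`, is next to be tested in this assay. It differs from compound 2 by methyl in place of hydrogen on a sulfur. Among the compounds with values here, no step between measured compounds shows what such a change does in this assay. Since compound 2 sits at the limit, only a move toward higher toxicity could appear as a number, and none beyond the scatter is expected. The expected step is a step that the limit leaves unreadable from compound 2 to compound 3. Compound 3 is accordingly estimated at 150000 nM, ranging from 40000 nM to 600000 nM, most probably reported again as a limit.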

Compound 3, concentration lethal to 50% of the cells: > 100000 nM
Compound 3: no number, only a limit; the forecaster's own chance of this, stated with the estimate: 80%; the middle value is on the limit's open side.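

In this assay compound 2 and compound 3 both sit at a limit of the assay, so no step can be read between them: the limit of > 100000 nM in this assay, at which 3 of the 3 values shown sit.

The compounds shown leave open whether methyl in place of hydrogen on a sulfur changes cytotoxicity at all, and which change would yield a measurable value.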